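Swapping a benzyl arm for tert-butyl on the imidazole core

The compounds below may be only part of what the source reports. "The series", "measured", "known", "first", "only" and "open" are said of these compounds alone.

Compound 1 `Cc1cccc(Cc2cnc(CCc3ccc(-c4ccccc4C(=O)O)cc3)[nH]2)c1` in an in vitro functional assay on cells for agonist activity at Bombesin receptor subtype-3 (Mus musculus), read by luminescence and calcium flux (a higher number here means that more compound is needed for the effect, a lower number that less compound is needed), gives 75 nM.
Compound 2 `O=C(O)c1ccccc1-c1ccc(CCc2ncc(Cc3cccc(F)c3)[nH]2)cc1` in this assay gives 7.9 nM.
Compound 3 `O=C(O)c1ccccc1-c1ccc(CCc2ncc(Cc3ccc(F)cc3)[nH]2)cc1` in this assay gives 50 nM.

Compound 3 stands second highest of the three numbers: close to compound 1, as a 1.5-fold lower number from compound 1 to compound 3 (0.18 log units; within the scatter) shows, and well above compound 2, as a 6.3-fold higher number from compound 2 to compound 3 (0.80 log units; beyond the scatter) shows.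

Compound 4 `CC(C)(C)c1cnc(CCc2ccc(-c3ccccc3C(=O)O)cc2)[nH]1` differs from compound 3 by tert-butyl in place of 4-fluorobenzyl on an aromatic carbon. Among the compounds with values here, none of the measured steps removes the six-membered aromatic ring at this position; they only move or exchange a small substituent on it. Those steps show that this arm matters: the small exchange from compound 3 to compound 2 gave a step beyond the scatter, whereas the exchange from compound 1 to compound 3 stayed within it. Losing the ring altogether is a larger change than either, and with no precedent among the measured compounds the direction is uncertain; a higher number appears more likely than a lower one. Compound 4 is therefore expected to give 150 nM, in a range from 30 nM to 800 nM, an estimated 3.0-fold higher number from compound 3 to compound 4 (0.48 log units; beyond the scatter).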

Compound 4, half-maximal effective concentration: 2750 nM
The estimate for compound 4 lay 18-fold (1.26 log units) below the measured number; measured number outside the range, above it.
By their numbers in this assay, from the lowest: compound 2; then compounds 3 and 1 (each within the scatter of the next); then compound 4.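

In this assay, within the data shown here, the tert-butyl arm stands apart from all three benzyl arms: the change gives a 55-fold higher number from compound 3 to compound 4 (1.74 log units; beyond the scatter) and a 350-fold higher number from compound 2 to compound 4 (2.54 log units; beyond the scatter) and a 37-fold higher number from compound 1 to compound 4 (1.56 log units; beyond the scatter) in turn, all larger than any step among the earlier compounds. So whichever small substituent the benzyl ring carries in these compounds, the number stays far lower than with tert-butyl, which has no ring and fewer heavy atoms. No measurement available here explains why the number rises so steeply.

Because tert-butyl both removes the aromatic ring and shrinks the arm, the compounds shown cannot separate these two changes. A cyclohexylmethyl arm, which keeps a ring that is not aromatic, or an open hexyl chain, which has no ring at all, would help tell them apart.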